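Replacing the Nitrophenyl Amide of Compound 1

The source may report more compounds than this note shows. Statements on the series, on what has been measured and on what is new or still open speak of the compounds shown alone.

Compound 1 `O=C(CSc1nc(Nc2ccccc2)c2ccccc2n1)Nc1cccc([N+](=O)[O-])c1` carries a 3-nitrophenyl group on the amide nitrogen of the shared core. Going by the values given here, in a functional assay on MGC-803 cells (Homo sapiens) for inhibition, read by MTT assay, with a stated time of 72 h (on this read-out lower numbers stand for stronger inhibition and higher numbers for weaker inhibition), compound 1 gives 28100 nM, the highest of the three numbers measured so far. Among the compounds with values here, two analogues change only that group. Compound 2 `C=CC(=O)Nc1cccc(NC(=O)CSc2nc(Nc3ccccc3)c3ccccc3n2)c1`, in which (vinylcarbonyl)amino stands in place of nitro, gives 7310 nM in this assay; the step is a 3.8-fold lower number from compound 1 to compound 2 (0.58 log units; beyond the scatter). Compound 3 `O=C(CSc1nc(Nc2ccccc2)c2ccccc2n1)Nc1ccc(C(F)(F)F)cc1`, with 4-(trifluoromethyl)phenyl in place of 3-nitrophenyl, gives 8670 nM; the step is a 3.2-fold lower number from compound 1 to compound 3 (0.51 log units; beyond the scatter). Between those two analogues, a 1.2-fold higher number from compound 2 to compound 3 (0.07 log units; within the scatter).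

Compound 4 `O=C(CSc1nc(Nc2ccccc2)c2ccccc2n1)Nc1ccc(Cl)c(Cl)c1` has not yet been measured. It differs from compound 1 in one place: 3,4-dichlorophenyl in place of 3-nitrophenyl on an amide-type nitrogen. Within the data shown here, no measured step involves 3,4-dichlorophenyl, so the expectation rests on the two steps already seen from compound 1, each of which removed the 3-nitrophenyl group and lowered the number by a modest amount beyond the scatter. A change of the same kind is expected here, so compound 4 is estimated at 10000 nM, with a range from 4000 nM to 25000 nM. This estimate means a step of a 2.8-fold lower number from compound 1 to compound 4 (0.45 log units; beyond the scatter), expected to be modest in size but beyond the scatter.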

Compound 4, half-maximal inhibitory concentration: 37900 nM
Compound 4: the middle estimate sits 3.8-fold (0.58 log units) below what was measured, outside the stated range (above it).
By their numbers in this assay, from the lowest: compounds 2 and 3 (each within the scatter of the next); then compounds 1 and 4 (each within the scatter of the next).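

In this assay, taking the 3-nitrophenyl group off the amide-type nitrogen does not in itself lower the number: 3,4-dichlorophenyl in its place gives a 1.3-fold higher number from compound 1 to compound 4 (0.13 log units; within the scatter) and so leaves compound 4 level with compound 1. Going by these compounds alone, the lower numbers of compounds 2 and 3 therefore go with the groups those two compounds carry, not with the loss of 3-nitrophenyl, which the earlier steps could not separate. This position also tells the groups apart, since the change to 3,4-dichlorophenyl gives a 4.4-fold higher number from compound 3 to compound 4 (0.64 log units; beyond the scatter) and also a 5.2-fold higher number from compound 2 to compound 4 (0.71 log units; beyond the scatter) in this series. Compounds 2 and 3 stay within the scatter of each other.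

Still open, going by these compounds, is whether an amine, a carboxylic acid or a 4-chlorophenyl group on the amide-type nitrogen would fall with compounds 2 and 3 or with compounds 1 and 4. Nothing measured here accounts for the split between these two pairs.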